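A few compounds are considered here, and "the series" means these few. Any claim that something is new, unique, unknown or untested is made for them only; others in the source may bear on it.

Working notes on the series. In an ADME assay on Vero cells (Chlorocebus sabaeus) for cytotoxicity, read by resazurin assay, with a stated time of 72 h (on this read-out higher numbers stand for lower toxicity in this test and lower numbers for higher toxicity in this test), compound 1 `CCCCC1(CCCC)C[C@@H](CO)[C@@](C)(OC)OO1` gives "not determined" (no result reported), so compound 1 has no result in this assay. Within the data shown here, compound 2 `CCCCC1(CCCC)C[C@@H](CNCCCn2ccnc2)[C@@](C)(OC)OO1` is the only member with a number in this assay: compound 2 gives 74500 nM, so it stands alone, with no second value to set it against. Compound 3 `CCCCC1(CCCC)C[C@@H](CNCCCn2ccnc2)[C@@](CCCC)(OC)OO1` differs from compound 2 by propyl in place of hydrogen on a saturated chain carbon bound to a saturated ring carbon. Among the measured compounds shown here, no step between measured compounds exists here, so any expectation for this change rests on compound 2 alone. The step from compound 2 to compound 3 is expected to be small, at most a modest move toward greater toxicity, estimated as a 1.2-fold lower number from compound 2 to compound 3 (0.09 log units; within the scatter), and possibly nothing beyond the scatter. For compound 3 the estimate in this assay is 60000 nM, with a range from 25000 nM to 150000 nM.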

Compound 3, half-maximal cytotoxic concentration: 32500 nM
Compound 3: middle estimate off by 1.8-fold (0.27 log units), on the high side; measured number inside the range.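

In this assay, propyl in place of hydrogen on a saturated chain carbon bound to a saturated ring carbon gives a 2.3-fold lower number from compound 2 to compound 3 (0.36 log units; beyond the scatter) and so moves the read-out beyond the scatter, toward higher toxicity in this test. Among these compounds, this is the first readable step at this position, and it rests on a single pair of compounds. Nothing measured here gives a reason for this shift.

As far as these compounds go, whether a longer chain such as hexyl would lower the number further remains open, as does the effect of a carboxylic acid at this position. Also open, from the compounds shown here alone, is whether the step would hold with a different amine side chain on the shared core.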